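Amino for chloro on two benzyl-substituted cores

The compounds below may be only part of what the source reports. "The series", "measured", "known", "first", "only" and "open" are said of these compounds alone.

Measured compounds:
compound 1 `ClCc1ccccc1Cn1cnc2c(Cl)nc(Cl)nc21`: 3380 nM
compound 2 `ClCc1cccc(Cn2cnc3c(Cl)nc(Cl)nc32)c1`: 3160 nM
compound 3 `Nc1nc(Cl)c2ncn(Cc3ccccc3CCl)c2n1`: 6610 nM

In a functional assay on HCC 2998 cells (Homo sapiens) for cytotoxicity, read by sulforhodamine B assay, with a stated time of 48 h (on this read-out higher numbers stand for weaker inhibition of growth and lower numbers for stronger inhibition of growth), compound 1 gives 3380 nM and compound 2 gives 3160 nM, a pair of values that lie within the scatter of each other. Compound 3 `Nc1nc(Cl)c2ncn(Cc3ccccc3CCl)c2n1` carries the change amino in place of chloro on an aromatic carbon relative to compound 1, and in this assay compound 3 gives 6610 nM; the step of a 2.0-fold higher number from compound 1 to compound 3 (0.29 log units; within the scatter) is within the scatter. The difference between the cores of compound 1 and compound 2 is not broken down here. Compound 4 `Nc1nc(Cl)c2ncn(Cc3cccc(CCl)c3)c2n1` is not yet measured; it differs from compound 2 by amino in place of chloro on an aromatic carbon, the same change as between compound 1 and compound 3, made on the other core. Among the measured compounds shown here, because the earlier step was a 2.0-fold higher number from compound 1 to compound 3 (0.29 log units; within the scatter), a step of similar size is expected for compound 4, namely a 2.0-fold higher number from compound 2 to compound 4 (0.30 log units; within the scatter), resting on the single precedent. For compound 4 in this assay the estimate is 6300 nM, expected to fall between 3000 nM and 13000 nM.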

Compound 4, concentration for total growth inhibition: 4890 nM
Beside the measured number, compound 4's estimate is 1.3-fold (0.11 log units) above it; the measured number falls inside the stated range.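

In this assay, amino in place of chloro on an aromatic carbon gives a 1.5-fold higher number from compound 2 to compound 4 (0.19 log units; within the scatter). Set beside the earlier step, the change looks alike on the two cores: the same change on two cores in this assay, a 2.0-fold higher number (0.29 log units; within the scatter) from compound 1 to compound 3 and a 1.5-fold higher number (0.19 log units; within the scatter) from compound 2 to compound 4, 1.3-fold (0.10 log units) apart, within the scatter of two such steps. This shows that the change carries from one core to the other without a difference that can be told apart, but it does not show a real effect of the change on either core, and two cores are too few to support a wider rule.

The compounds shown leave open how a methylamino group, a methoxy group or a thiol would read in the same place. They also leave open whether the step would hold with a longer chain in place of the chloromethyl arm.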